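The source may hold more compounds than are shown below. What is called first, only, known or untested is meant among the compounds shown, and "the series" means these compounds.

In a functional assay on SH-SY5Y cells (Homo sapiens) for cytotoxicity, read by MTT assay, with a stated time of 72 h (a higher number here means a weaker inhibitor, a lower number a stronger inhibitor), compound 2 `O=C1c2c[n+]([O-])c3ccccc3c2C(=O)c2c1c1ccccc1n2CCCCN1CCNCC1` stands at 1240 nM, the higher of the two numbers. Compound 1 `CC1(C)OCC(Cn2cc(Cn3c4c(c5ccccc53)C(=O)c3c[n+]([O-])c5ccccc5c3C4=O)nn2)O1` stands at 230 nM. The gap between these two numbers lies beyond the scatter. Compound 3 `CC1(C)O[C@@H](CO)[C@H](Cn2cc(Cn3c4c(c5ccccc53)C(=O)c3c[n+]([O-])c5ccccc5c3C4=O)nn2)O1` gives only a limit, > 1000 nM.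

Next is compound 4 `CN1CCN(CCCCCCn2c3c(c4ccccc42)C(=O)c2c[n+]([O-])c4ccccc4c2C3=O)CC1`, with the change 2-(4-methylpiperazin-1-yl)ethyl in place of piperazin-1-yl on a saturated chain carbon, four bonds along the chain from an aromatic nitrogen.

Within the data shown here, the only measured step, an at least 4.3-fold higher number from compound 1 to compound 3 (0.63 log units; beyond the scatter), concerns a different group, 2,2-dimethyl-1,3-dioxolan-4-yl, and gives no direct guide to this change. Among the measured compounds shown here, it shows only that a side-chain change can exceed the scatter.

With compound 2 at 1240 nM as the anchor, no step beyond the scatter is expected in this assay. The estimated step is a 1.1-fold lower number from compound 2 to compound 4 (0.05 log units; within the scatter), with no firm direction. For compound 4 the expected value is 1100 nM, with an estimated range of 350 nM to 3500 nM.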

Compound 4, half-maximal inhibitory concentration: 920 nM
The estimate for compound 4 lay 1.2-fold (0.08 log units) above the measured number; the measured number falls inside the stated range.
By their numbers in this assay, from the lowest: compound 1; then compounds 4 and 2 (each within the scatter of the next).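

In this assay, among these compounds, 2-(4-methylpiperazin-1-yl)ethyl in place of piperazin-1-yl gives a 1.3-fold lower number from compound 2 to compound 4 (0.13 log units; within the scatter), the first reading at this place, on a saturated chain carbon, four bonds along the chain from an aromatic nitrogen. The longer chain and the added methyl arrive together in this single change, so the effect of each cannot be read separately. Nothing measured here accounts for the step.

Still open, going by these compounds, is whether a morpholine or a primary amine in place of piperazin-1-yl would give a step beyond the scatter.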